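Moving the chlorine around the outer ring

The source may report more compounds than this note shows. Statements on the series, on what has been measured and on what is new or still open speak of the compounds shown alone.

Measured so far in an assay on HEK293 cells for inhibition of N-acylethanolamine-hydrolyzing acid amidase (Rattus norvegicus), read by LC-MS, with a stated time of 30 min; a lower number here means a stronger inhibitor, a higher number a weaker inhibitor:
compound 1 `O=C(CCc1ccc(-c2cccc(F)c2)cc1)N1CCCC1` gives 1800 nM;
compound 2 `O=C(CCc1ccc(-c2ccccc2Cl)cc1)N1CCCC1` gives only an assay limit, > 100000 nM;
compound 3 `O=C(CCc1ccc(-c2cccc(Cl)c2)cc1)N1CCCC1` gives 25400 nM.

Compound 3 has the highest of the two numbers; its nearest neighbour is compound 1, with a 14-fold higher number from compound 1 to compound 3 (1.15 log units; beyond the scatter). Moving the chlorine gave an at least 3.9-fold lower number from compound 2 to compound 3 (0.59 log units; beyond the scatter). Compound 4 `O=C(CCc1ccc(-c2ccc(Cl)cc2)cc1)N1CCCC1` shifts it once more: 4-chlorophenyl in place of 3-chlorophenyl on an aromatic carbon. Going by the values given here, no measured step moves a chlorine from the 3-position to the 4-position, so both earlier steps bear only loosely on this one; they show that position and halogen each shift the number a lot. For compound 4 a change within the scatter or a modest one in either direction is expected, giving an estimated step of a 1.3-fold lower number from compound 3 to compound 4 (0.10 log units; within the scatter). Compound 4 is estimated at 20000 nM, within 4000 nM to 100000 nM.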

Compound 4, half-maximal inhibitory concentration: 48600 nM
Estimate against measurement, compound 4: 2.4-fold (0.39 log units) below; measured number inside the range.
By their numbers in this assay, from the lowest: compound 1; then compounds 3 and 4 (each within the scatter of the next). At a limit, above all of these: compound 2.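

With a 1.9-fold higher number from compound 3 to compound 4 (0.28 log units; within the scatter), the 3-chlorophenyl and 4-chlorophenyl groups cannot be told apart. The 4-chlorophenyl group also leaves a wide gap to the 3-fluorophenyl group, with a 27-fold higher number from compound 1 to compound 4 (1.43 log units; beyond the scatter). The 2-chlorophenyl group stands apart, with an at least 2.0-fold lower number from compound 2 to compound 4 (0.31 log units; beyond the scatter), but compound 2 has only an assay limit, so this step has no exact size: the limit of > 100000 nM in this assay, at which 1 of the 4 values shown sits.

Going by these compounds, what remains open is how a 4-fluorophenyl group would compare with the 3-fluorophenyl group. On these data alone, it is also open whether a methoxy group or a carboxylic acid on the outer ring would give a number lower than that of compound 1.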